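The source may hold more compounds than are shown below. What is called first, only, known or untested is meant among the compounds shown, and "the series" means these compounds.

In a functional assay on KYSE-450 cells (Homo sapiens) for inhibition, read by MTT assay, with a stated time of 48 h (a higher number here means a weaker inhibitor, a lower number a stronger inhibitor), compound 2 (`C/C=C/C(=O)N(Cc1ccc(OC)c(OC)c1)c1cc(OC)c(OC)c(OC)c1`) gives 39100 nM. Compound 3 (`COC(=O)c1cc(CNc2cc(OC)c(OC)c(OC)c2)ccc1OC`) gives 41100 nM, which lies within the scatter of compound 2. Compound 1 (`COCC(=O)N(Cc1ccc(OC)c(O)c1)c1cc(OC)c(OC)c(OC)c1`) gives 460 nM, a much lower number, beyond the scatter from compound 2. Compound 4 (`C/C=C/C(=O)N(Cc1ccc(OC)c(Br)c1)c1cc(OC)c(OC)c(OC)c1`) differs from compound 2 in one place: bromo in place of methoxy on an aromatic carbon. Among the measured compounds shown here, no measured pair isolates this change, and compound 1 differs from compound 2 in more than one place, so the expectation is loose. For the measured compounds named here, compound 1 at 460 nM shows only that far lower numbers occur in this small set. A moderate move to a lower number, beyond the scatter, is expected: a 6.5-fold lower number from compound 2 to compound 4 (0.81 log units; beyond the scatter). For compound 4 the estimated value is 6000 nM, with an expected range of 800 nM to 40000 nM.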

Compound 4, half-maximal inhibitory concentration: 10500 nM
Estimate against measurement, compound 4: 1.8-fold (0.24 log units) below; low and high end bracket the measured number.
By their numbers in this assay, from the lowest: compound 1; then compound 4; then compounds 2 and 3 (each within the scatter of the next).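

In this assay, bromo can replace methoxy on this aromatic carbon, ortho to a methoxy group and meta to a large group, without loss of activity: a 3.7-fold lower number from compound 2 to compound 4 (0.57 log units; beyond the scatter). Among the compounds shown here, this modest step is the first single-place change that can be read, and it shows that this methoxy is not required for the activity of compound 2. No available data explain the shift. On these data alone, whether a chloro, a methyl or an amine on this carbon would read like bromo remains open. As far as these compounds go, whether the step carries over to compounds with another acyl group on the shared core also remains open.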